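Adding Ethyl to the Ester Chain of Compound 2

This account rests on a few compounds, and the source may have more. Where it says the series, first, only, none or still open, it means among the compounds named here.

Measured so far in a functional assay on A549 cells (Homo sapiens) for antiproliferative activity, read by MTT assay, with a stated time of 48 h (on this read-out higher numbers stand for weaker inhibition and lower numbers for stronger inhibition), are these two compounds:

- compound 1 (`CC(C)=CCC[C@]1(C)/C=C/[C@@H](OC(=O)C=C(C)C)[C@](C)(O)/C=C/C(=O)/C(CN2CCCC2)=C\C1`) gives 180 nM
- compound 2 (`CC(=O)O[C@@H]1/C=C/[C@@](C)(CCC=C(C)C)C/C=C(/CO)C(=O)/C=C/[C@@]1(C)O`) gives 8670 nM

Of these two, compound 2 has the higher number, 8670 nM, so it is the weaker inhibitor, and its gap to compound 1 lies beyond the usual scatter. The two compounds differ in more than one place, so this gap cannot be pinned on any single structural change.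

Compound 3 (`CCCC(=O)O[C@@H]1/C=C/[C@@](C)(CCC=C(C)C)C/C=C(/CO)C(=O)/C=C/[C@@]1(C)O`) has not yet been measured. It departs from compound 2 in one place (ethyl in place of hydrogen on a saturated chain carbon bound to a carbonyl carbon): ethyl in place of hydrogen on a saturated chain carbon bound to a carbonyl carbon, which turns acetoxy into (propylcarbonyl)oxy.

Within the data shown here, no measured pair shows this change on its own, so the expectation here is only a cautious one. A small step towards stronger inhibition is expected, possibly none beyond the scatter. The expected step is a 1.4-fold lower number from compound 2 to compound 3 (0.16 log units; within the scatter) in this assay, and it remains an estimate. The estimated value for compound 3 is 6000 nM, with an expected range from 2500 nM to 14000 nM as its limits of likely outcome.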

Compound 3, half-maximal inhibitory concentration: 4100 nM
The estimate for compound 3 lay 1.5-fold (0.17 log units) above the measured number, within the range that was stated.
By their numbers in this assay, from the lowest: compound 1; then compound 3; then compound 2.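

In this assay, the ester chain of compound 2 proves open to change: ethyl in place of hydrogen on a saturated chain carbon bound to a carbonyl carbon, which turns acetoxy into (propylcarbonyl)oxy, gives a 2.1-fold lower number from compound 2 to compound 3 (0.33 log units; beyond the scatter) and so moves the read-out towards stronger inhibition. Among these compounds, this is the first change that can be read on its own, since the earlier gap involved differences in more than one place; it shows that this position tolerates the added ethyl without any loss of inhibition, although the gain is modest and only just clears the usual scatter. No measurement at hand speaks to what lies behind this step, so it stands as an observation without a known cause.

A single step cannot show whether inhibition would keep improving with a longer chain such as pentyl, or how a branched isopropyl group or a terminal amine on the same chain would behave. It also leaves open whether the same change would have a similar effect on the core of compound 1, which differs from compound 2 in more than one place.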